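This account rests on a few compounds, and the source may have more. Where it says the series, first, only, none or still open, it means among the compounds named here.

Compound 3, with the structure `O=C(CSc1ncccn1)N/N=c1/scc(-c2ccc([N+](=O)[O-])cc2)n1-c1ccccc1`, was tested in an ADME assay on NIH3T3 cells (Mus musculus) for cytotoxicity, read by MTT assay, with a stated time of 24 h (a higher number here means a weaker inhibitor, a lower number a stronger inhibitor), where compound 3 gives 193 ug/mL. Its closest neighbour is compound 1, built as `Cc1nnc(SCC(=O)N/N=c2/scc(-c3ccc([N+](=O)[O-])cc3)n2-c2ccccc2)s1`, and in this assay compound 1 gives 177 ug/mL; the two differ only in the group on the sulfur, and the step of a 1.1-fold higher number from compound 1 to compound 3 (0.04 log units; within the scatter) lies within the scatter, so the two numbers cannot be told apart. Compound 2, built as `Cc1ccc(-c2cs/c(=N/NC(=O)CSc3nnnn3-c3ccccc3)n2-c2ccccc2)cc1`, carries the 1-phenyl-1H-tetrazol-5-yl group on the sulfur, and in this assay compound 2 reaches only > 500 ug/mL, which is a limit of the assay and not a number.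

Compound 4 has the structure `O=C(CSc1nnnn1-c1ccccc1)N/N=c1/scc(-c2ccc([N+](=O)[O-])cc2)n1-c1ccccc1`. Compared with compound 3 the change is 1-phenyl-1H-tetrazol-5-yl in place of pyrimidin-2-yl on a sulfur. For the measured compounds named here, the single measured step that touches the sulfur group, a 1.1-fold higher number from compound 1 to compound 3 (0.04 log units; within the scatter), was within the scatter, so swapping one ring for another at this position has so far moved nothing. Going by the values given here, the group that enters, however, is the one borne by compound 2, whose value sits at the limit of > 500 ug/mL in this assay, at which 1 of the 3 values shown sits. Weighing both, a step of a 1.6-fold higher number from compound 3 to compound 4 (0.19 log units; within the scatter) towards a weaker inhibitor is expected, and compound 4 is estimated to give 300 ug/mL, between 150 ug/mL and 600 ug/mL.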

Compound 4, half-maximal inhibitory concentration: 14.3 ug/mL
Compound 4: the middle estimate sits 21-fold (1.32 log units) above what was measured; the measured number lies below the stated range.
By their numbers in this assay, from the lowest: compound 4; then compounds 1 and 3 (each within the scatter of the next). At a limit, above all of these: compound 2.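

Until now, swapping one ring for another on the sulfur had changed nothing, but in this assay the 1-phenyl-1H-tetrazol-5-yl group changes the result sharply, both against pyrimidin-2-yl (a 13-fold lower number from compound 3 to compound 4 (1.13 log units; beyond the scatter)) and against 5-methyl-1,3,4-thiadiazol-2-yl (a 12-fold lower number from compound 1 to compound 4 (1.09 log units; beyond the scatter)). The group does not do this alone, since the step with nitro in place of methyl on an aromatic carbon is also large (an at least 34-fold lower number from compound 2 to compound 4 (1.54 log units; beyond the scatter)), so among these compounds the low number appears only where nitro and the 1-phenyl-1H-tetrazol-5-yl group occur together. The value of compound 2 in that step is a limit of the assay and not a number: the limit of > 500 ug/mL in this assay, at which 1 of the 4 values shown sits.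

From the compounds shown here alone, what remains open is whether the pairing depends on nitro itself or would survive with an amine or a chlorine atom on that aromatic carbon. It is also unclear whether the effect belongs to the tetrazole ring or to its phenyl group, which a 1-methyl-1H-tetrazol-5-yl group on the sulfur would help to separate.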